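Furan-2-yl for 2-phenylethenyl: next step in the series

This account rests on a few compounds, and the source may have more. Where it says the series, first, only, none or still open, it means among the compounds named here.

Measured so far in a functional assay on ileum for antagonist activity at muscarinic acetylcholine receptor M3 (Cavia porcellus); on this read-out higher numbers stand for weaker inhibition and lower numbers for stronger inhibition:
- compound 1 `O=C(CN1CCC(N2CCCC2)CC1)C(O)(c1ccccc1)C1CCCCC1`, compound 1 gives 349 nM
- compound 2 `O=C(CN1CCN(C/C=C\c2ccccc2)CC1)C(O)(c1ccccc1)C1CCC1`, compound 2 gives 9.92 nM
- compound 3 `O=C(CN1CCN(C(c2ccccc2)c2ccccc2)CC1)C(O)(c1ccccc1)C1CCC1`; for compound 3 only the assay limit is reached, > 10000 nM, so it is not a number (the limit of > 10000 nM in this assay, at which 1 of the 3 values shown sits).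

Compound 2 holds the lowest of the two numbers given; compound 1 sits a wide gap higher, beyond the scatter. Compound 4 `O=C(CN1CCN(Cc2ccco2)CC1)C(O)(c1ccccc1)C1CCC1` has not been measured. It differs from compound 2 by furan-2-yl in place of 2-phenylethenyl on a saturated chain carbon bound to an amine nitrogen in a ring. Within the data shown here, no step between measured compounds isolates this change. The expectation is a moderate rise for compound 4, beyond the scatter, with a 4.0-fold higher number from compound 2 to compound 4 (0.61 log units; beyond the scatter) as the estimated step. Compound 4 is expected to give about 40 nM, between 8 nM and 200 nM.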

Compound 4, antagonist equilibrium constant: 750 nM
Compound 4: the middle estimate sits 19-fold (1.27 log units) below what was measured; measured number outside the range, above it.
By their numbers in this assay, from the lowest: compound 2; then compound 1; then compound 4. At a limit, above all of these: compound 3.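

In this assay, among these compounds, furan-2-yl in place of 2-phenylethenyl on a saturated chain carbon bound to an amine nitrogen in a ring gives a 76-fold higher number from compound 2 to compound 4 (1.88 log units; beyond the scatter) and thus shows, for the first time, that this place is sensitive to the group it carries. The change swaps the ring type and also removes the double bond, so these differences cannot be read apart. No measurement at hand accounts for the size of this step.

Going by these compounds, whether the ring or the shorter chain drives the step stays open. A benzyl group, or furan-2-yl on a longer chain with a double bond, would separate the two.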